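Aryl swap on the saturated ring carbon of compound 1

A few compounds are considered here, and "the series" means these few. Any claim that something is new, unique, unknown or untested is made for them only; others in the source may bear on it.

Measured so far:
compound 1, `CC1=C(C(=O)Nc2ccc(F)c(Cl)c2)C(c2cccc(O)c2)NC(=S)N1`, 50100 nM
compound 2, `CC1=C(C(=O)Nc2ccc(F)c(Cl)c2)C(c2cccc(Oc3ccccc3)c2)NC(=O)N1`, 40700 nM

Both were tested in a functional assay on HOP-92 cells (Homo sapiens) for cytotoxicity, read by sulforhodamine B assay, with a stated time of 48 h; a higher number here means a weaker inhibitor of growth, a lower number a stronger inhibitor of growth. Compound 1 gives 50100 nM and compound 2 gives 40700 nM; the two numbers lie within the scatter of each other, so no order between them can be read. Compound 1 holds the highest of the two numbers, with compound 2 nearest. For the measured compounds named here, compound 2 differs from compound 1 in more than one place, so no single step between them is counted.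

Compound 3 is `CC1=C(C(=O)Nc2ccc(F)c(Cl)c2)C(c2ccccc2Cl)NC(=S)N1`. Relative to compound 1 the change is 2-chlorophenyl in place of 3-hydroxyphenyl on a saturated ring carbon. Going by the values given here, no measured step of this kind exists here, and the two measured compounds sit close together, so the expected step in this assay is a 1.3-fold lower number from compound 1 to compound 3 (0.10 log units; within the scatter), within the scatter, with no clear direction. Compound 3 is estimated at 40000 nM, with a range from 15000 nM to 100000 nM.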

Compound 3, concentration for 50% growth inhibition: 50100 nM
Estimate against measurement, compound 3: 1.3-fold (0.10 log units) below; the range from low to high includes it.
By their numbers in this assay, from the lowest: compounds 2, 1 and 3 (each within the scatter of the next).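

In this assay, for the compounds shown here, the swap gives no change at the digits printed from compound 1 to compound 3 (within the scatter) and this is the first single-place step read at the saturated ring carbon. Here 3-hydroxyphenyl, with 1 hydrogen-bond donor and 1 hydrogen-bond acceptor, gives way to 2-chlorophenyl, with 0 of each, and the substituent and its ring place on the aryl group change together without any shift in the number. No measurement on these compounds bears on why the number holds.

With a single step, and all three compounds within the scatter of one another, nothing yet shows that this position can move the number in either direction. From the compounds shown here alone, whether an amine or a carboxylic acid on the aryl ring, or a longer chain in place of that ring, would shift it remains open.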